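Pyrrolidin-1-yl for 4-methylpiperazin-1-yl on the carbonyl

The source may report more compounds than this note shows. Statements on the series, on what has been measured and on what is new or still open speak of the compounds shown alone.

Measured compounds in a functional assay on IMR-32 cells (Homo sapiens) for antiproliferative activity, read by sulforhodamine B assay, with a stated time of 48 h (on this read-out higher numbers stand for weaker inhibition and lower numbers for stronger inhibition), and their values
- compound 1 `COc1ccc(C[C@@H](O)/C=C/C=C/C(=O)N2CCN(C)CC2)cc1OC` with 18900 nM
- compound 2 `COc1ccc(C[C@@H](O)/C=C/C=C/C(=O)N2CCN(c3ccccc3)CC2)cc1OC` with 9430 nM
- compound 3 `COc1ccc(C[C@@H](O)/C=C/C=C/C(=O)N2CCN(C(c3ccccc3)c3ccccc3)CC2)cc1OC` with 11900 nM

In this assay compound 1 at 18900 nM stands level with compounds 2 and 3, with both gaps from it inside the usual scatter. Compound 4 `COc1ccc(C[C@@H](O)/C=C/C=C/C(=O)N2CCCC2)cc1OC` has not yet been measured. Going by the values given here, it keeps the core of compound 1 and carries pyrrolidin-1-yl in place of 4-methylpiperazin-1-yl on a carbonyl carbon as its only change. Among the compounds with values here, the one measured step that bears on this, a 2.0-fold lower number from compound 1 to compound 2 (0.30 log units; within the scatter) for phenyl in place of methyl on an amine nitrogen in a ring, stayed within the scatter. Within the data shown here, no measured compound replaces the ring itself, so the evidence for this change is indirect. The expected change, a 1.4-fold lower number from compound 1 to compound 4 (0.13 log units; within the scatter) in this assay is therefore no step beyond the scatter. Compound 4 is estimated at 14000 nM with an expected range from 7000 nM to 28000 nM in this assay once it is tested.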

Compound 4, half-maximal inhibitory concentration: 12000 nM
Compound 4: middle estimate off by 1.2-fold (0.07 log units), on the high side; low and high end bracket the measured number.
By their numbers in this assay, from the lowest: compounds 2, 3, 4 and 1 (each within the scatter of the next).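

The earlier compounds shown here varied only the group on the ring nitrogen, whereas here the ring itself changes. In this assay, pyrrolidin-1-yl in place of 4-methylpiperazin-1-yl on the carbonyl carbon gives a 1.6-fold lower number from compound 1 to compound 4 (0.20 log units; within the scatter). So at this position, a five-membered ring with 1 hetero atom and a six-membered ring with 2 hetero atoms cannot be told apart in this read-out, and the amide need not carry the 4-methylpiperazin-1-yl group for its number to stay level with that of compound 1. Nothing available explains this result, and no measurement beyond the antiproliferative numbers bears on it.

From the compounds shown here alone, it remains open whether an amide without a ring, such as diethylamino, or a morpholin-4-yl group on the same carbonyl carbon would also stay level. Going by these compounds, it is equally open whether any group at this position can move the number beyond the scatter.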